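The source may hold more compounds than are shown below. What is called first, only, known or untested is meant among the compounds shown, and "the series" means these compounds.

Series notes, a functional assay on HT-29 cells (Homo sapiens) for antiproliferative activity, read by sulforhodamine B assay, with a stated time of 48 h; on this read-out higher numbers stand for weaker inhibition and lower numbers for stronger inhibition. Compound 1 `CCCCN1CCN(c2ccc(S(=O)(=O)Oc3cccc(F)c3)cc2)C1=O` gives 76000 nM in this assay. Compound 2 `CCCCN1CCN(c2ccc(S(=O)(=O)Oc3cccc(Br)c3)cc2)C1=O`, differing only by bromo in place of fluoro on an aromatic carbon, gives 16000 nM in this assay, and the step is a 4.8-fold lower number from compound 1 to compound 2 (0.68 log units; beyond the scatter). Among the measured compounds shown here, on the two numbers so far compound 2 stands lowest, with compound 1 its only neighbour and a wide gap between them.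

Compound 3 `CCCCN1CCN(c2ccc(S(=O)(=O)Oc3ccc(F)c(F)c3)cc2)C1=O` is not yet measured. Its change from compound 2: 3,4-difluorophenyl in place of 3-bromophenyl on an oxygen. For the measured compounds named here, the single measured step bears on this only in part: fluoro to bromo on the aromatic carbon read a 4.8-fold lower number from compound 1 to compound 2 (0.68 log units; beyond the scatter), so a return to fluorine alone would be expected to push the number back toward that of compound 1. Going by the values given here, the second fluorine of the 3,4-difluorophenyl has no measured counterpart, so its contribution is open. Taken together, a modest rise in the number is expected, estimated as a 2.8-fold higher number from compound 2 to compound 3 (0.45 log units; beyond the scatter), with the result sitting between the two measured values rather than beyond either. Compound 3 is therefore expected at 45000 nM in this assay, with a range of 15000 nM to 140000 nM.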

Compound 3, half-maximal inhibitory concentration: > 100000 nM
Compound 3: a limit, no number (the forecaster's own chance of this, stated with the estimate: 15%); middle value at least 2.2-fold (0.34 log units) from the limit.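

In this assay compound 3 gives > 100000 nM, which is a limit of the assay and not a number. On the oxygen whose other neighbour is the sulfonyl sulfur, 3,4-difluorophenyl in place of 3-bromophenyl gives an at least 6.2-fold higher number from compound 2 to compound 3 (0.79 log units; beyond the scatter), so among these three compounds the 3-bromophenyl compound, compound 2, keeps the lowest number, and both fluorinated compounds read clearly higher. Fluoro in place of hydrogen on an aromatic carbon gives an at least 1.3-fold higher number from compound 1 to compound 3 (0.11 log units; that floor lies within the scatter), so the added fluorine recovers none of the ground held by compound 2, although no rise over compound 1 can be claimed from a floor of this size.

On these data alone, the true size of both new steps stays unknown, and so does the contribution of the second fluorine beyond what the floor shows: the limit of > 100000 nM in this assay, at which 1 of the 3 values shown sits. Also open, as far as these compounds go, is whether the low number of compound 2 is particular to bromo or would also appear with chloro, methyl or methoxy on the phenyl ring, and whether a longer chain or an amine on the shared core would move the numbers.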